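The source may report more compounds than this note shows. Statements on the series, on what has been measured and on what is new or still open speak of the compounds shown alone.

Compounds measured in a functional assay on DU-145 cells (Homo sapiens) for inhibition, read by trypan blue exclusion, with a stated time of 72 h; a lower number here means a stronger inhibitor, a higher number a weaker inhibitor:

Compound 1, `Cn1c(=O)c(S(=O)(=O)c2ccc(C(=O)O)cc2)cc2cnc(Nc3ccc4[nH]ccc4c3)nc21`: 10000 nM
Compound 2, `Cn1c(=O)c(S(=O)(=O)c2ccc(F)cc2F)cc2cnc(Nc3ccc4occc4c3)nc21`: 15000 nM
Compound 3, `Cn1c(=O)c(S(=O)(=O)c2ccc(F)cc2F)cc2cnc(Nc3ccccn3)nc21`: 75000 nM

Compound 1 gives the lowest of the three numbers in this assay, but its gap to compound 2 is within the scatter, so no order between compound 1 and compound 2 can be read from these values; only compound 3 lies clearly apart. For the measured compounds named here, the one step measured within the set is a 5.0-fold higher number from compound 2 to compound 3 (0.70 log units; beyond the scatter), and it concerns the substituent on the amino nitrogen of the shared core, not the sulfonyl side.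

Compound 4, `Cn1c(=O)c(S(=O)(=O)Nc2ccc(F)cc2)cc2cnc(Nc3ccc4[nH]ccc4c3)nc21`, differs from compound 1 by (4-fluorophenyl)amino in place of 4-carboxyphenyl on a sulfonyl sulfur. Going by the values given here, no measured pair in the set changes the group on the sulfonyl sulfur, so the step from compound 1 to compound 4 has no direct precedent here. The measured step at the amino side, a 5.0-fold higher number from compound 2 to compound 3 (0.70 log units; beyond the scatter), gives no guide to it. The expectation is therefore a lower number than compound 1 by a modest margin, with wide uncertainty: the step is estimated as a 2.5-fold lower number from compound 1 to compound 4 (0.40 log units; beyond the scatter). In this assay compound 4 is expected at 4000 nM, with a range from 800 nM to 20000 nM.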

Compound 4, half-maximal inhibitory concentration: 5000 nM
Compound 4: middle estimate off by 1.3-fold (0.10 log units), on the low side, and the stated range covers the measured number.
By their numbers in this assay, from the lowest: compounds 4, 1 and 2 (each within the scatter of the next, the first and the last beyond it); then compound 3.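

For the compounds shown here, this is the first reading at the sulfonyl sulfur: in this assay, with the amino side held constant, a 2.0-fold lower number from compound 1 to compound 4 (0.30 log units; within the scatter). The 4-carboxyphenyl and (4-fluorophenyl)amino groups are therefore not told apart by this assay, even though the change removes the carboxylic acid and places a nitrogen on the sulfonyl sulfur. No further data are available to explain this result.

Because the acid, the fluorine and the nitrogen all change together, the contribution of each remains unresolved. A plain phenyl or a phenylamino group on the sulfonyl sulfur would help to separate them, and an alkylamine there would test whether an aromatic ring is needed at all.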